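This account rests on a few compounds, and the source may have more. Where it says the series, first, only, none or still open, it means among the compounds named here.

Measured so far:
- compound 1, `CCc1nc2c(-c3ccc(Cl)cc3Cl)ccnc2n1[C@@H](CC)C1CC1`, gives 0.4 nM in an assay for binding affinity to Corticotropin releasing factor receptor (Rattus norvegicus); on this read-out lower numbers stand for stronger inhibition and higher numbers for weaker inhibition
- compound 2, `CCCC(C)n1c(CC)nc2c(-c3ccc(C(C)O)cc3Cl)ccnc21`, gives 5.1 nM in this assay

Compound 1 holds the lower of the two numbers; the gap to compound 2 is beyond the usual scatter, so on these two values compound 1 is the stronger binder of the pair. For the measured compounds named here, no single-point step between measured compounds is available, so the size of a stereochemical change is not yet known from the data.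

Compound 3, `CCc1nc2c(-c3ccc(Cl)cc3Cl)ccnc2n1[C@H](CC)C1CC1`, is the unmeasured partner of compound 1. the two compounds have the same atoms and bonds and differ only in configuration as drawn: 1 of 1 stereo elements differ; a stereocentre at a saturated chain carbon is drawn S in compound 1 and R in compound 3 Nothing leaves and nothing enters; only the configuration at the saturated chain carbon is drawn differently.

In this assay a loss is expected rather than a gain: inverting the single stereocentre is expected to give a weaker result than compound 1, with the step of a 25-fold higher number from compound 1 to compound 3 (1.40 log units; beyond the scatter) expected to lie beyond the scatter, though its magnitude is uncertain in the absence of a measured comparison. For compound 3 the estimate is 10 nM, within 1 nM to 100 nM.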

Compound 3, inhibition constant: 0.2 nM
Compound 3: the middle estimate sits 50-fold (1.70 log units) above what was measured, outside the stated range (below it).
By their numbers in this assay, from the lowest: compounds 3 and 1 (each within the scatter of the next); then compound 2.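

Inverting the saturated chain carbon from S to R gives a 2.0-fold lower number from compound 1 to compound 3 (0.30 log units; within the scatter) in this assay, so this pair gives no sign that the drawn configuration at this position matters for the read-out. Before this pair, no single-place step was available, and the size of a stereochemical change in the series could not be read; it now has one measured example, and that example lies within the usual scatter. The comparison isolates this one stereocentre, with nothing else in the structure changing: the fact that compounds 1 and 3 differ only in the configuration as drawn.

This finding rests on a single pair carrying one set of groups, so it cannot yet be extended to the rest of the series, and it speaks only to this assay. As far as these compounds go, whether the two configurations stay equivalent with a longer chain, an amine or a carboxylic acid on the saturated chain, or with a different group in place of the second chlorine on the aryl ring, remains open.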